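Trading Chloromethyl for Vinyl on the Amide Carbonyl

A few compounds are considered here, and "the series" means these few. Any claim that something is new, unique, unknown or untested is made for them only; others in the source may bear on it.

Of the compounds shown here, three built on a shared core have been measured in a functional assay on Rec1 cells (Homo sapiens) for inhibition, read by luminescence and CellTiter-Glo, with a stated time of 72 h; a higher number here means a weaker inhibitor, a lower number a stronger inhibitor. Compound 1 `O=C(O)c1cc(-c2ccc(Oc3ccccc3)cc2)nn1C1CCCN(C(=O)CCl)C1` gives 2200 nM in this assay. Compound 2 `C=CC(=O)N1CCCC(n2nc(-c3ccc(Oc4ccccc4)cc3)cc2C(=O)O)C1` differs from compound 1 only by vinyl in place of chloromethyl on a carbonyl carbon, and that single swap produced a 23-fold higher number from compound 1 to compound 2 (1.36 log units; beyond the scatter). In this assay compound 2 gives 50000 nM. Compound 3 `O=C(CCl)Nc1cccc(Cn2nc(-c3ccc(Oc4ccccc4)cc3)cc2C(=O)O)c1` carries the same chloromethyl carbonyl group, but on a different part of the molecule; how its core differs from that of compound 1 is not broken down here. In this assay compound 3 gives 7100 nM.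

Compound 4 `C=CC(=O)Nc1cccc(Cn2nc(-c3ccc(Oc4ccccc4)cc3)cc2C(=O)O)c1` has not yet been measured. It differs from compound 3 by vinyl in place of chloromethyl on a carbonyl carbon. Among the compounds with values here, this is the same kind of change as the one from compound 1 to compound 2, though not the same: in compound 1 the carbonyl carbon's other neighbour is an amide-type nitrogen in a ring, whereas in compound 3 it is an amide-type nitrogen. Because the earlier swap gave a 23-fold higher number from compound 1 to compound 2 (1.36 log units; beyond the scatter), the expected step here is an 8.5-fold higher number from compound 3 to compound 4 (0.93 log units; beyond the scatter). Such a step would bring compound 4 near the level of compound 2, which gives 50000 nM in this assay. Compound 4 is therefore estimated at 60000 nM, most likely somewhere between 15000 nM and 200000 nM.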

Compound 4, half-maximal inhibitory concentration: 33100 nM
For compound 4 the middle estimate is 1.8-fold (0.26 log units) above the measured one; the measured number falls inside the stated range.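

In this assay the swap of chloromethyl for vinyl on the carbonyl carbon again points toward a weaker inhibitor and gives a 4.7-fold higher number from compound 3 to compound 4 (0.67 log units; beyond the scatter) on this second core. The direction of the change therefore carries over from one core to the other, but its size does not, so the step seen on one core cannot simply be copied onto the other: the same change on two cores in this assay, a 23-fold higher number (1.36 log units; beyond the scatter) from compound 1 to compound 2 and a 4.7-fold higher number (0.67 log units; beyond the scatter) from compound 3 to compound 4, 4.9-fold (0.69 log units) apart, beyond the scatter of two such steps. These two pairs show only that the direction was shared here; they do not explain why the size differs, and they cannot establish that the same direction would hold on any further core.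

The compounds shown leave open how the carbonyl carbon would respond to other groups, such as a plain methyl, a bromomethyl or a longer chain ending in a double bond. They also leave open whether a third core would give a step closer to the larger or the smaller of these two.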